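The source may hold more compounds than are shown below. What is called first, only, known or untested is meant among the compounds shown, and "the series" means these compounds.

Among the measured compounds shown here, in a functional assay on A498 cells (Homo sapiens) for inhibition, read by sulforhodamine B assay, with a stated time of 48 h (on this read-out higher numbers stand for weaker inhibition of growth and lower numbers for stronger inhibition of growth), compound 1 (`COc1cc(-c2nn(-c3cccc(NC(=O)Nc4ccc(Cl)c(Cl)c4)c3)cc2-c2ccncc2)ccc1Cl`) gives 4590 nM and its only measured neighbour, compound 2 (`O=C(Nc1cccc(-n2cc(-c3ccncc3)c(-c3ccc(Cl)c(O)c3)n2)c1)Nc1ccc(Cl)c(Cl)c1`), gives 3170 nM within the scatter of compound 1. Compound 3 (`COc1cc(-c2nn(-c3cccc(NC(=O)Nc4ccc(Cl)c(C(F)(F)F)c4)c3)cc2-c2ccncc2)ccc1Cl`) differs from compound 1 by trifluoromethyl in place of chloro on an aromatic carbon. For the measured compounds named here, the one measured step (a 1.4-fold lower number from compound 1 to compound 2 (0.16 log units; within the scatter)) concerns a different group, hydrogen in place of methyl on an oxygen, so it offers no direct guide to this change. No shift beyond the scatter is therefore expected in this assay, and the expected step is small (a 1.2-fold lower number from compound 1 to compound 3 (0.08 log units; within the scatter)). For compound 3 the estimate is 3800 nM (expected range 1800 nM to 8000 nM).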

Compound 3, concentration for total growth inhibition: 6970 nM
The estimate for compound 3 lay 1.8-fold (0.26 log units) below the measured number; the range from low to high includes it.
By their numbers in this assay, from the lowest: compounds 2, 1 and 3 (each within the scatter of the next, the first and the last beyond it).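

In this assay, exchanging 3,4-dichlorophenyl for 4-chloro-3-(trifluoromethyl)phenyl gives a 1.5-fold higher number from compound 1 to compound 3 (0.18 log units; within the scatter). This position, ortho to a chloro group, therefore accepts trifluoromethyl, with 4 heavy atoms in place of 1, without a shift beyond the scatter. Among the compounds shown here, the earlier step concerned only the oxygen on the other aromatic ring, so this is the first reading at this place. On these data alone, whether an amine or a carboxylic acid here would also stay within the scatter remains open. Nothing available bears on why this exchange gave this result.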